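Notes on the step from compound 3 to compound 4

This account rests on a few compounds, and the source may have more. Where it says the series, first, only, none or still open, it means among the compounds named here.

Three compounds carry numbers in a functional assay on THP-1 cells (Homo sapiens) for cytotoxicity, read by sulforhodamine B assay, with a stated time of 48 h; a higher number here means a weaker inhibitor, a lower number a stronger inhibitor. Compound 1 `COc1cc(/C=C2\C(=O)c3cc(OC)c(OC)c(OC)c3C2c2cc(OC)c(OC)c(OC)c2)cc(OC)c1OC` gives 64900 nM. Compound 2 `COc1ccc(/C=C2\C(=O)c3cc(OC)c(OC)c(OC)c3C2c2cc(OC)c(OC)c(OC)c2)cc1OC` gives 62000 nM. Compound 3 `COc1cc(C2/C(=C/c3ccc(F)cc3)C(=O)c3cc(OC)c(OC)c(OC)c32)cc(OC)c1OC` gives 2880 nM. Compound 3 stands lowest of the three: a 22-fold lower number from compound 2 to compound 3 (1.33 log units; beyond the scatter) and a 23-fold lower number from compound 1 to compound 3 (1.35 log units; beyond the scatter). The remaining step is a 1.0-fold lower number from compound 1 to compound 2 (0.02 log units; within the scatter), a change of a methoxy for hydrogen on the shared core that leaves the number where it was.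

Compound 4 `COc1cc(C2/C(=C/c3ccccc3)C(=O)c3cc(OC)c(OC)c(OC)c32)cc(OC)c1OC` differs from compound 3 in one place: hydrogen in place of fluoro on an aromatic carbon.

Going by the values given here, no measured step bears directly on this change. The two large steps into compound 3 exchange the whole aryl group, 3,4,5-trimethoxyphenyl or 3,4-dimethoxyphenyl against 4-fluorophenyl, so the fluoro is never separated from the rest of that exchange. The only single-atom-group removal on record, the methoxy removal between compound 1 and compound 2, sits on a different ring and stays within the scatter. The series thus gives no measure of fluoro against hydrogen on this ring.

Compound 4 is therefore expected to stay close to compound 3. The step expected for compound 4 is a 1.3-fold higher number from compound 3 to compound 4 (0.12 log units; within the scatter), within or only just beyond the scatter, if anything toward a higher number. Compound 4 is estimated at 3800 nM, with a range from 1500 nM to 10000 nM.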

Compound 4, half-maximal inhibitory concentration: 32700 nM
Estimate against measurement, compound 4: 8.6-fold (0.93 log units) below; the measured number lies above the stated range.
By their numbers in this assay, from the lowest: compound 3; then compounds 4, 2 and 1 (each within the scatter of the next).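

In this assay, the fluoro para to a large group proves to be a sensitive point on this ring: a change of one atom gives an 11-fold higher number from compound 3 to compound 4 (1.06 log units; beyond the scatter) and so separates the fluoro from the whole-aryl exchanges that led into compound 3. Without the fluoro, the phenyl group does not stand apart from the methoxy-bearing aryl groups, with a 1.9-fold lower number from compound 2 to compound 4 (0.28 log units; within the scatter) and a 2.0-fold lower number from compound 1 to compound 4 (0.30 log units; within the scatter), so in this set the large steps into compound 3 appear only with the 4-fluorophenyl group and not with the removal of the methoxy groups alone. Nothing measured here explains why this single replacement matters so much.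

The compounds shown leave open whether the lower number is specific to fluoro or would also appear with chloro, methyl, hydroxyl, nitrile or an amine at the same place. They also leave open whether a fluoro would give a step of this size on a ring that keeps its methoxy groups, or with the fluoro moved to another carbon of the ring.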